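Replacing the carbamoyl group of compound 3

A few compounds are considered here, and "the series" means these few. Any claim that something is new, unique, unknown or untested is made for them only; others in the source may bear on it.

Measured in an ADME assay on Huh-7 cells (Homo sapiens) for cytotoxicity, with a stated time of 72 h; on this read-out lower numbers stand for higher toxicity in this test and higher numbers for lower toxicity in this test:
compound 1 `CCOc1cccc2c1S(=O)(=O)N=C2C1=C(O)[C@H](C(C)(C)C)N(CCC(C)(C)C)C1=O` gives > 33000 nM as a limit
compound 2 `CC(C)(C)[C@H]1C(O)=C(C2=NS(=O)(=O)c3c(OCc4ncon4)cccc32)C(=O)N1Cc1ccc(F)c(Cl)c1` gives > 33000 nM as a limit
compound 3 `CC(C)(C)CCN1C(=O)C(C2=NS(=O)(=O)c3c(OCC(N)=O)cccc32)=C(O)[C@@H]1C(C)(C)C` gives > 33000 nM as a limit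

Compound 3 has no exact number on this read-out, only the limit > 33000 nM in this assay as its result. It stands with the other two compounds under the limit of > 33000 nM in this assay, at which 3 of the 3 values shown sit, and so cannot be ranked against them.

Compound 4 `CC(C)(C)CCN1C(=O)C(C2=NS(=O)(=O)c3c(OCc4ncon4)cccc32)=C(O)[C@@H]1C(C)(C)C` differs from compound 3 as follows: 1,2,4-oxadiazol-3-yl in place of carbamoyl on a saturated chain carbon bound to an oxygen on an aromatic ring and the same difference reads carbamoylmethoxy to (1,2,4-oxadiazol-3-yl)methoxy.

Among the compounds with values here, the one measured step at this place is a step that the two limits leave unreadable from compound 1 to compound 3 and so offers no size to carry over. Compound 2 carries the same (1,2,4-oxadiazol-3-yl)methoxy group and gives > 33000 nM as a limit too. On that evidence, no step beyond the usual scatter is expected, in either direction, and another limit is the likeliest report. The estimated step is a number no higher from compound 3 to compound 4 (the limit leaves the size open) as an expectation only. For compound 4 the estimate is 33000 nM with an expected range from 15000 nM to 60000 nM in this test.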

Compound 4, half-maximal cytotoxic concentration: > 33000 nM
Compound 4: no number, only a limit; the forecaster's own chance of this, stated with the estimate: 85%; the middle value sits exactly at the limit.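

In this assay compound 4 gives > 33000 nM, which is a limit and not a number. No step from compound 1, compound 2 or compound 3 to compound 4 can be read, because all four results share one limit: the limit of > 33000 nM in this assay, at which 4 of the 4 values shown sit.

The compounds shown leave open how their true values compare and whether exchanging carbamoyl for 1,2,4-oxadiazol-3-yl changes the read-out at all.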